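Chloro in place of fluoro in the 3,5-difluorophenyl series

The compounds below may be only part of what the source reports. "The series", "measured", "known", "first", "only" and "open" are said of these compounds alone.

Values in a functional assay on cells (leukaemia cell line, Homo sapiens) for inhibition, read by sulforhodamine B assay, with a stated time of 48 h (a higher number here means a weaker inhibitor of growth, a lower number a stronger inhibitor of growth), for the measured compounds:
- compound 1 `O=S(=O)(Nc1ccc(Cl)c(Cl)c1)c1ccc(-c2cnc(C3CC3)o2)cc1` gives 416 nM
- compound 2 `O=S(=O)(Nc1ccc(F)cc1F)c1ccc(-c2cnc(C3CC3)o2)cc1` gives 356 nM
- compound 3 `O=S(=O)(Nc1cc(F)cc(F)c1)c1ccc(-c2cnc(C3CC3)o2)cc1` gives 2140 nM

Compound 3 stands highest of the three, and its gaps to the other two lie beyond the scatter. The next step leads to compound 4 `O=S(=O)(Nc1cc(F)cc(Cl)c1)c1ccc(-c2cnc(C3CC3)o2)cc1` and is described as chloro in place of fluoro on an aromatic carbon in the exchange of chloro in place of fluoro on an aromatic carbon, taking 3,5-difluorophenyl to 3-chloro-5-fluorophenyl.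

Going by the values given here, two measured steps bear on it: a 5.1-fold higher number from compound 1 to compound 3 (0.71 log units; beyond the scatter) and a 6.0-fold higher number from compound 2 to compound 3 (0.78 log units; beyond the scatter). By contrast, a 1.2-fold lower number from compound 1 to compound 2 (0.07 log units; within the scatter) shows no separation between the other two compounds. Among the compounds with values here, neither of the two larger steps is the same exchange, and no measured pair isolates a single swap of fluoro for chloro, so the evidence is indirect. Within the data shown here, compound 1, the only measured compound with chloro groups, gives 416 nM and offers some ground for expecting a lower number, covering only part of that distance. The expected change in this assay is a 2.1-fold lower number from compound 3 to compound 4 (0.33 log units; beyond the scatter) as an estimate. For compound 4 the estimated value is 1000 nM with an expected range of 400 nM to 2400 nM in this assay.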

Compound 4, concentration for 50% growth inhibition: 1440 nM
Compound 4: middle estimate off by 1.4-fold (0.16 log units), on the low side, and the stated range covers the measured number.
By their numbers in this assay, from the lowest: compounds 2 and 1 (each within the scatter of the next); then compounds 4 and 3 (each within the scatter of the next).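

Chloro in place of fluoro on an aromatic carbon, meta to a fluoro group, is the first single-atom exchange in the series, and in this assay it gives a 1.5-fold lower number from compound 3 to compound 4 (0.17 log units; within the scatter); at this position the exchange therefore does not separate the two compounds. The separation from the other two aryl patterns remains with 3-chloro-5-fluorophenyl, as shown by a 4.0-fold higher number from compound 2 to compound 4 (0.61 log units; beyond the scatter) and a 3.5-fold higher number from compound 1 to compound 4 (0.54 log units; beyond the scatter), so a single chloro does not bring this series to the level of the 2,4-difluorophenyl or 3,4-dichlorophenyl compounds. No measurement in hand accounts for this result.

Open, on these data alone, is whether 3,5-dichlorophenyl, or a methoxy or an amine in place of the chloro of compound 4, would move the number beyond the scatter in this assay. Also open, as far as these compounds go, is which feature of the aryl patterns in compound 1 and compound 2 sets them apart from compound 4, since these compounds differ from it at more than one ring carbon.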